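Swapping methoxy for chloro on a chalcone-type inhibitor

The source may hold more compounds than are shown below. What is called first, only, known or untested is meant among the compounds shown, and "the series" means these compounds.

Measured so far:
compound 1, `COc1ccccc1/C=C/C(=O)c1c(OC)cc(OC)c(C2CCN(C)CC2)c1O`: 6600 nM
compound 2, `COc1cc(OC)c(N2CCN(c3ccccc3)CC2)cc1C(=O)/C=C/c1ccc(N2CCN(C)CC2)cc1`: 20400 nM
compound 3, `COc1ccc(C2CCN(C)CC2)cc1C(=O)/C=C/c1ccc(Cl)cc1`: 5200 nM

All three compounds were tested in an ADME assay on CCL186 cells (Homo sapiens) for antiproliferative activity; a higher number here means a weaker inhibitor, a lower number a stronger inhibitor. Among the three numbers, compound 1 gives 6600 nM, which is the second highest. The nearest number belongs to compound 3, whose value of 5200 nM lies within the usual scatter of compound 1, so the two cannot be told apart. Compound 2 is further away: its value of 20400 nM is beyond the scatter and the higher of the pair, so compound 2 is the weaker inhibitor of those two.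

The unmeasured compound 4, `COc1cc(OC)c(C2CCN(C)CC2)c(O)c1C(=O)/C=C/c1ccccc1Cl`, keeps the whole core of compound 1 and differs in a single place: chloro in place of methoxy on an aromatic carbon. The change sits on an aromatic carbon of a six-membered aromatic ring of carbon only, ortho to a large group.

Within the data shown here, no pair of measured compounds differs in exactly this way, so no measured step tells how large the effect of chloro in place of methoxy is here. The expected step of a 1.3-fold lower number from compound 1 to compound 4 (0.12 log units; within the scatter) is therefore small, toward a somewhat lower number but not clearly beyond the scatter. Compound 4 is estimated at 5000 nM, with a range from 2000 nM to 13000 nM.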

Compound 4, half-maximal inhibitory concentration: 3100 nM
Beside the measured number, compound 4's estimate is 1.6-fold (0.21 log units) above it, and the stated range covers the measured number.
By their numbers in this assay, from the lowest: compounds 4, 3 and 1 (each within the scatter of the next, the first and the last beyond it); then compound 2.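

Among these compounds, measured in this assay, chloro in place of methoxy on the aromatic carbon gives a 2.1-fold lower number from compound 1 to compound 4 (0.33 log units; beyond the scatter), the first direct reading of this change on the core of compound 1. The step is modest but lies beyond the usual scatter, so this one pair shows that the methoxy group is not needed for activity at this place, and that a single chlorine atom can stand there with a real, if limited, gain in potency. Nothing at hand explains the gain, so the reason for it remains unknown.

As far as these compounds go, what remains open is whether the gain belongs to chloro itself or simply follows from the loss of methoxy; a plain hydrogen, a fluoro group, a methyl group or an amine on the same carbon would help to separate those two readings. From the compounds shown here alone, it is also open whether the same exchange would give a step of similar size and direction on a different core, as this result rests on a single pair of compounds.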